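Arylthio-methyl benzamides: naphthyl in place of dimethylphenyl

The source may hold more compounds than are shown below. What is called first, only, known or untested is meant among the compounds shown, and "the series" means these compounds.

Measured so far:
compound 1 `Cc1ccc(SCc2ccc(/C=C/C(=O)Nc3ccccc3N)cc2)cc1` — 48.3%
compound 2 `Cc1cc(C)cc(SCc2ccc(/C=C/C(=O)Nc3ccccc3N)cc2)c1` — 47.3%
compound 3 `COc1ccc(SCc2ccc(C(=O)Nc3ccccc3N)cc2)cc1` — 70.7%

All three were run in a functional assay on A549 cells (Homo sapiens) for inhibition, read by CCK-8 assay, with a stated time of 72 h, tested at 8 uM; a lower number here means less inhibition of growth, a higher number more inhibition of growth at the concentration tested. Compound 2 `Cc1cc(C)cc(SCc2ccc(/C=C/C(=O)Nc3ccccc3N)cc2)c1` gives 47.3%; compound 1 `Cc1ccc(SCc2ccc(/C=C/C(=O)Nc3ccccc3N)cc2)cc1` gives 48.3%, and the two sit within the scatter of each other. Compound 3 `COc1ccc(SCc2ccc(C(=O)Nc3ccccc3N)cc2)cc1` gives 70.7%, which lies beyond the scatter above compound 2; compound 3, however, differs from compound 2 in two places, so its gap to compound 2 is not a single-point step and is only recorded as it stands.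

The step now followed goes from compound 2 to compound 4 `Nc1ccccc1NC(=O)/C=C/c1ccc(CSc2cccc3ccccc23)cc1`: naphthalen-1-yl in place of 3,5-dimethylphenyl on a sulfur. Going by the values given here, the only measured step of the same kind, an exchange of the aryl group on the sulfur, is a number 1 percentage points lower from compound 1 to compound 2 (within the scatter), which did not move the read-out beyond the scatter. Among the compounds with values here, on that basis the exchange in compound 4 is expected to give little or no change in this assay, a number 4.7 percentage points higher from compound 2 to compound 4 (within the scatter), with a wide band because the naphthalen-1-yl group has no precedent among the measured compounds. Compound 4 is therefore estimated at 52%, with a range from 35% to 70%.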

Compound 4, percent growth inhibition at one concentration: 71.2%
Beside the measured number, compound 4's estimate is 19.2 percentage points below it, outside the stated range (above it).
By their numbers in this assay, from the lowest: compounds 2 and 1 (each within the scatter of the next); then compounds 3 and 4 (each within the scatter of the next).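

In this assay, the aryl group on a sulfur proves able to move the read-out: naphthalen-1-yl in place of 3,5-dimethylphenyl gives a number 23.9 percentage points higher from compound 2 to compound 4 (beyond the scatter), and naphthalen-1-yl in place of 4-methylphenyl gives a number 22.9 percentage points higher from compound 1 to compound 4 (beyond the scatter). The earlier exchange at this position, between the two methyl-bearing phenyl groups, gave only a number 1 percentage points lower from compound 1 to compound 2 (within the scatter), so this position is not indifferent to the group it carries, as that step alone might have suggested. Going by these compounds alone, both larger steps involve the same entering group, with 2 six-membered aromatic rings of carbon only in place of one, but compound 4 is the only example, and no measurement here explains the rise.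

As far as these compounds go, it remains open whether the rise is specific to naphthalen-1-yl or also extends to other two-ring groups on the same sulfur, such as naphthalen-2-yl or quinolinyl. From the compounds shown here alone, it is also open whether a single phenyl ring carrying a tert-butyl group or a second phenyl group would reach the level of compound 4, or whether a saturated cyclohexyl group on the sulfur would bring the read-out back towards that of compound 1 and compound 2.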